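Swapping Cyclohexyl for Phenyl on a Shared Amide

The source may report more compounds than this note shows. Statements on the series, on what has been measured and on what is new or still open speak of the compounds shown alone.

Of the compounds shown here, two built on one shared core have been tested. In a toxicity assay on L02 cells (Homo sapiens) for inhibition, read by CCK-8 assay, with a stated time of 72 h (a higher number here means a weaker inhibitor, a lower number a stronger inhibitor), compound 1 `CC(C)(C)OC(=O)N1CCN(C(=O)Cn2cc(CN3C(=O)C(=O)c4c(Cl)ccc(Cl)c43)nn2)CC1` gives 42000 nM. Compound 2 `O=C(Cn1cc(CN2C(=O)C(=O)c3c(Cl)ccc(Cl)c32)nn1)NC1CCCCC1` gives 83900 nM in this assay, the higher of the two numbers as they stand, though its gap to compound 1 lies within the scatter. Compound 3 `O=C(Cn1cc(CN2C(=O)C(=O)c3c(Cl)ccc(Cl)c32)nn1)Nc1ccccc1` differs from compound 2 by phenyl in place of cyclohexyl on an amide-type nitrogen. Going by the values given here, no step of this kind has been measured here. Because compound 2 gives 83900 nM close to compound 1, the step of a 1.2-fold lower number from compound 2 to compound 3 (0.08 log units; within the scatter) is expected to be none beyond the scatter. Compound 3 is therefore expected to give 70000 nM, somewhere between 25000 nM and 200000 nM.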

Compound 3, half-maximal inhibitory concentration: 24900 nM
Beside the measured number, compound 3's estimate is 2.8-fold (0.45 log units) above it; measured number outside the range, below it.
By their numbers in this assay, from the lowest: compounds 3, 1 and 2 (each within the scatter of the next, the first and the last beyond it).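

On this amide-type nitrogen, the kind of ring matters in this assay: replacing a non-aromatic ring with an aromatic one of the same six carbons gives a 3.4-fold lower number from compound 2 to compound 3 (0.53 log units; beyond the scatter) and marks a modest but real change. Cyclohexyl and phenyl have equal counts of heavy atoms, hydrogen-bond donors and hydrogen-bond acceptors, so these counts do not separate compound 2 from compound 3. Nothing available explains the step. As far as these compounds go, whether a pyridyl ring or a benzyl group on this nitrogen would shift the number remains open. So does the effect of adding a methoxy group to the phenyl ring.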